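The compounds below may be only part of what the source reports. "The series", "measured", "known", "first", "only" and "open" are said of these compounds alone.

Measured compounds:
compound 1 `COc1cc(COc2cccc(F)c2)nc(-c2ccccn2)n1` — 1260 nM
compound 2 `CCOc1cc(COc2cccc(F)c2)nc(-c2ccccn2)n1` — 251 nM
compound 3 `CCNc1cc(COc2cccc(F)c2)nc(-c2ccccn2)n1` — 631 nM

All three numbers come from a functional assay on cells for antagonist activity at Free fatty acid receptor 1 (Homo sapiens), read by TR-FRET and inositol phosphate accumulation, with a stated time of 2 h; on this read-out lower numbers stand for stronger inhibition and higher numbers for weaker inhibition. Compound 3 stands second highest of the three: its nearest neighbour is compound 1, and the step of a 2.0-fold lower number from compound 1 to compound 3 (0.30 log units; within the scatter) lies within the scatter; its furthest is compound 2, with a 2.5-fold higher number from compound 2 to compound 3 (0.40 log units; beyond the scatter) beyond the scatter.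

Compound 4 `CC(C)Nc1cc(COc2cccc(F)c2)nc(-c2ccccn2)n1` differs from compound 3 by methyl in place of hydrogen on a saturated chain carbon bound to a nitrogen on an aromatic ring and a saturated chain carbon, which read one bond further out is ethylamino to isopropylamino. Among the compounds with values here, the one measured step of the same kind sits on the oxygen side, a 5.0-fold lower number from compound 1 to compound 2 (0.70 log units; beyond the scatter), a methyl added on the saturated chain carbon bound to the oxygen on the aromatic ring. Within the data shown here, no measured pair shows whether the nitrogen side follows the same course; a 2.5-fold higher number from compound 2 to compound 3 (0.40 log units; beyond the scatter) concerns the linking atom, not the chain. Some lowering in this assay is therefore expected, held back from the full size of a 5.0-fold lower number from compound 1 to compound 2 (0.70 log units; beyond the scatter) since it rests on a single precedent. For compound 4 the expected step is a 2.0-fold lower number from compound 3 to compound 4 (0.29 log units; within the scatter). Compound 4 is thus estimated at 320 nM, with a range from 120 nM to 850 nM.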

Compound 4, half-maximal inhibitory concentration in the Free fatty acid receptor 1 assay: 100 nM
For compound 4 the middle estimate is 3.2-fold (0.51 log units) above the measured one; the whole stated range lies above it.
By their numbers in the Free fatty acid receptor 1 assay, from the lowest: compound 4; then compound 2; then compounds 3 and 1 (each within the scatter of the next).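

In the Free fatty acid receptor 1 assay, methyl in place of hydrogen on the saturated chain carbon bound to the nitrogen gives a 6.3-fold lower number from compound 3 to compound 4 (0.80 log units; beyond the scatter), so a change that had a single precedent on the oxygen side now appears on both, at matching size: the same change on two cores in the Free fatty acid receptor 1 assay, a 5.0-fold lower number (0.70 log units; beyond the scatter) from compound 1 to compound 2 and a 6.3-fold lower number (0.80 log units; beyond the scatter) from compound 3 to compound 4, 1.3-fold (0.10 log units) apart, within the scatter of two such steps With the isopropylamino group, the comparison with the alkoxy compounds also shifts, giving a 2.5-fold lower number from compound 2 to compound 4 (0.40 log units; beyond the scatter) and a 13-fold lower number from compound 1 to compound 4 (1.10 log units; beyond the scatter), which leaves compound 4 with the lowest number of the four, its steps to all others beyond the scatter. In a physicochemical assay for lipophilicity, at pH 7.4 (a higher number here means a more lipophilic compound, a lower number a more polar compound), compound 3 gives 3.9 and compound 4 gives 4.3 so that the same methyl comes with a higher number: the measured distribution coefficient of compound 3, 3.9, and of compound 4, 4.3, a number 0.40 log units higher (beyond the scatter)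

From the compounds shown here alone, whether the number keeps falling with tert-butylamino or cyclopropylamino remains open. Going by these compounds, without the isopropoxy compound, the linking atom cannot be compared on the branched chain, and it is unknown whether a hydroxyl on the chain would keep the gain in the Free fatty acid receptor 1 assay while lowering the number in the physicochemical assay.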